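A few compounds are considered here, and "the series" means these few. Any claim that something is new, unique, unknown or untested is made for them only; others in the source may bear on it.

Compound 1 `Cc1cccc(NNC(=O)c2cccc(NS(=O)(=O)c3cnc(O)nc3O)c2)c1` is one of three compounds that have been measured in a functional assay on A549 cells (Homo sapiens) for antiproliferative activity, read by MTT assay, with a stated time of 24 h; a higher number here means a weaker inhibitor, a lower number a stronger inhibitor. Compound 1 gives > 20000 nM, which is a limit of the assay and not a number. Compound 2 `O=C(NNc1ccccc1Cl)c1ccccc1NS(=O)(=O)c1cnc(O)nc1O` gives 5480 nM. Compound 3 `O=C(NNc1ccc(F)cc1)c1ccccc1NS(=O)(=O)c1cnc(O)nc1O` gives > 20000 nM, again a limit rather than a number. Among the compounds with values here, the only step measured between two compounds that differ in one place is an at least 3.6-fold higher number from compound 2 to compound 3 (0.56 log units; beyond the scatter). Compound 4 `O=C(NNC(=O)c1cccc(NS(=O)(=O)c2cnc(O)nc2O)c1)c1cccc(Cl)c1` differs from compound 1 by (3-chlorophenyl)carbonyl in place of 3-methylphenyl on an amine nitrogen. Within the data shown here, no measured step touches this part of the structure, and the step from compound 2 to compound 3 alters a different group, so it offers no direct guide. Compound 1 sits at the limit of > 20000 nM in this assay, at which 2 of the 3 values shown sit, which leaves room in both directions. Compound 4 is therefore expected at 15000 nM, between 3000 nM and 40000 nM, an estimated step of an at least 1.3-fold lower number from compound 1 to compound 4 (0.12 log units; that floor lies within the scatter) held only loosely.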

Compound 4, half-maximal inhibitory concentration: 6000 nM
Compound 4: middle estimate off by 2.5-fold (0.40 log units), on the high side; the measured number falls inside the stated range.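

Putting (3-chlorophenyl)carbonyl in place of 3-methylphenyl gives an at least 3.3-fold lower number from compound 1 to compound 4 (0.52 log units; beyond the scatter), so in this assay this place on an amine nitrogen responds to a change of group, which the earlier step, made at a different group, could not show. The true size of this step stays unknown, because compound 1 stands at a limit of the assay and not at a number: the limit of > 20000 nM in this assay, at which 2 of the 4 values shown sit.

The carbonyl and the chlorine enter together, so the compounds shown leave open which of them matters. They also leave open how an unsubstituted phenylcarbonyl or a longer alkyl chain would fare here.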